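A few compounds are considered here, and "the series" means these few. Any claim that something is new, unique, unknown or untested is made for them only; others in the source may bear on it.

Measured so far in a functional assay on DU-145 cells (Homo sapiens) for cytotoxicity, read by MTT assay, with a stated time of 48 h; on this read-out lower numbers stand for stronger inhibition and higher numbers for weaker inhibition:

- compound 1, `COc1ccc(-c2cc(C(=O)Nc3nc4ccc(Cl)cc4s3)nc3cc(-c4ccccc4)nn23)cc1OC`: 9330 nM
- compound 2, `COc1cc(-c2cc(C(=O)Nc3nc4ccc(Cl)cc4s3)nc3cc(-c4ccccc4)nn23)cc(OC)c1OC`: 38900 nM
- compound 3, `COc1ccc(-c2cc(C(=O)Nc3nc4cc(C)c(C)cc4s3)nc3cc(-c4ccccc4)nn23)cc1`: 12300 nM

Compound 1 and compound 2 share a core and differ in one place, (methoxy in place of hydrogen on an aromatic carbon); this change gives a 4.2-fold higher number from compound 1 to compound 2 (0.62 log units; beyond the scatter). Compound 3 carries a different core; the difference between the core of compound 3 and that of compound 1 is not broken down here. What the two values show is that compound 3 and compound 1 sit within the scatter of each other in this assay, while compound 2 stands beyond the scatter from both.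

Compound 4, `COc1ccc(-c2cc(C(=O)Nc3nc4cc(C)c(C)cc4s3)nc3cc(-c4ccccc4)nn23)cc1OC`, is not yet measured. It differs from compound 3 by methoxy in place of hydrogen on an aromatic carbon. Among the compounds with values here, this is the same kind of change as the one from compound 1 to compound 2, not the same: in compound 1 the entering methoxy sits on a carbon that is also meta to a methoxy group, whereas in compound 3 the carbon is ortho to a methoxy group and meta to a large group only.

Within the data shown here, the single comparable step, a 4.2-fold higher number from compound 1 to compound 2 (0.62 log units; beyond the scatter), is the only guide, and it rests on one pair with a different core. On that basis a step of a 2.8-fold higher number from compound 3 to compound 4 (0.45 log units; beyond the scatter) is expected from the value of compound 3, 12300 nM, though with wide uncertainty given that the surroundings of the changed carbon are not identical. Compound 4 is therefore estimated at 35000 nM in this assay, with a range from 12000 nM to 100000 nM.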

Compound 4, half-maximal inhibitory concentration: 6910 nM
The estimate for compound 4 lay 5.1-fold (0.70 log units) above the measured number; the whole stated range lies above it.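

Methoxy in place of hydrogen on an aromatic carbon does not carry over unchanged between these two cores in this assay: the same change on two cores in this assay, a 4.2-fold higher number (0.62 log units; beyond the scatter) from compound 1 to compound 2 and a 1.8-fold lower number (0.25 log units; within the scatter) from compound 3 to compound 4, 7.4-fold (0.87 log units) apart, beyond the scatter of two such steps

On the core of compound 3 this change leaves the number within the scatter, a 1.8-fold lower number from compound 3 to compound 4 (0.25 log units; within the scatter), so the loss seen on the core of compound 1 does not recur here, and exchanging the 6-chloro-1,3-benzothiazol-2-yl for the 5,6-dimethyl-1,3-benzothiazol-2-yl on the 3,4-dimethoxyphenyl compounds also gives a step within the scatter, a 1.4-fold lower number from compound 1 to compound 4 (0.13 log units; within the scatter). This does not show that the core alone sets the size of the step, since each step rests on a single pair and the methoxy enters a different ring setting in each, 4-methoxyphenyl in compound 3 against the ring of compound 1, so core and ring setting cannot be told apart.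

Still open, as far as these compounds go, is what a further methoxy on the ring of compound 4 would do, which would set the same ring setting on both cores and separate the two influences. Also open, from the compounds shown here alone, is whether a hydroxy group, an amine or a longer chain such as ethoxy in the place of the entering methoxy would follow either step in this assay.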